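This account rests on a few compounds, and the source may have more. Where it says the series, first, only, none or still open, it means among the compounds named here.

Compound 1 `CN(C)C(=O)C1CCN(c2ccc(Cl)c(C(F)(F)F)c2)C1` and compound 2 `CN1CN(C(=O)C2CCN(c3ccc(Cl)c(C(F)(F)F)c3)C2)CC1=O` share one core and differ only in the group on the carbonyl carbon. In an assay on cells for inhibition of Palmitoleoyl-protein carboxylesterase NOTUM variant C330S (Homo sapiens), read by fluorescence, with a stated time of 40 min (on this read-out lower numbers stand for stronger inhibition and higher numbers for weaker inhibition), compound 1 gives 1200 nM and compound 2 gives 1400 nM; compound 1 holds the lowest of the two numbers, and the step of a 1.2-fold higher number from compound 1 to compound 2 (0.07 log units; within the scatter) lies within the scatter. Compound 3 `O=c1[nH]nc(C2CCN(c3ccc(Cl)c(C(F)(F)F)c3)C2)o1` has not yet been measured in this assay. Compared with compound 1 it carries a group of 6 heavy atoms (2 carbon, 2 nitrogen, 2 oxygen; one five-membered aromatic ring with 3 hetero atoms) in place of a group of 5 heavy atoms (3 carbon, 1 nitrogen, 1 oxygen; no ring), on a saturated ring carbon. Within the data shown here, only the step from compound 1 to compound 2 bears on this, and it shows that a different group at the carbonyl carbon gave a number within the scatter of compound 1; no measured step removes the whole dimethylcarbamoyl group, so the expectation rests loosely on that one step. Compound 3 is therefore expected to show a step of a 1.3-fold lower number from compound 1 to compound 3 (0.12 log units; within the scatter) in this assay, not clearly beyond the scatter. The estimate for compound 3 is 900 nM, within a range from 250 nM to 3500 nM.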

Compound 3, half-maximal inhibitory concentration: 4200 nM
The estimate for compound 3 lay 4.7-fold (0.67 log units) below the measured number, and the stated range ends below it.
By their numbers in this assay, from the lowest: compounds 1 and 2 (each within the scatter of the next); then compound 3.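

In this assay there is a 3.5-fold higher number from compound 1 to compound 3 (0.54 log units; beyond the scatter) when the dimethylcarbamoyl group on the saturated ring carbon gives way to a five-membered aromatic ring with 3 hetero atoms. Among these compounds, this is the first step here to go beyond the scatter, and it shows that the number at this position can move even when the incoming group has nearly the same count of heavy atoms as the one it replaces. No measurement at hand gives a reason for this step.

From the compounds shown here alone, this single swap changes the ring, the hydrogen-bond donor count and the acceptor count together, so it remains open which of these differences goes with the higher number. Going by these compounds, it also remains open how a carboxylic acid or a simple amine on the same ring carbon would compare with compound 1.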